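The source may hold more compounds than are shown below. What is called first, only, known or untested is meant among the compounds shown, and "the series" means these compounds.

Measured compounds:
Compound 1, `Cc1cc(C#N)nc(NNC(=O)Nc2cc(Cl)nc(Cl)c2)c1`: > 6600 nM
Compound 2, `Cc1cc(NNC(=O)Nc2cc(Cl)nc(Cl)c2)ncc1-c1cn(C)nc1C`: > 1400 nM

In a functional assay on CHO cells for antagonist activity at sphingosine 1-phosphate receptor 2 (Homo sapiens), read by fluorescence and calcium flux, with a stated time of 3 min (on this read-out lower numbers stand for stronger inhibition and higher numbers for weaker inhibition), compound 1 gives > 6600 nM, which is a limit of the assay and not a number. Compound 2 gives > 1400 nM in this assay, likewise a limit rather than a number. Compound 1 therefore stands nowhere firm: its own result is a limit, as is the only other result shown, so no order between the two can be read.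

Compound 3, `Cc1cc(NNC(=O)Nc2cc(Cl)nc(Cl)c2)nc(C(=O)NC2CC2)c1`, has not yet been measured. It differs from compound 1 by cyclopropylcarbamoyl in place of cyano on an aromatic carbon. Among the measured compounds shown here, no measured pair shows what such a change does in this assay. With both known results sitting at limits, the expectation for compound 3 is weak inhibition again, and the step of an at least 1.1-fold lower number from compound 1 to compound 3 (0.04 log units; that floor lies within the scatter) is expected to be no larger than the usual scatter. Compound 3 is thus estimated at 6000 nM, within 1500 nM to 30000 nM, with a real chance that only a limit is reported.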

Compound 3, half-maximal inhibitory concentration: 4500 nM
For compound 3 the middle estimate is 1.3-fold (0.12 log units) above the measured one, and the stated range covers the measured number.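

In this assay, putting cyclopropylcarbamoyl in place of cyano on an aromatic carbon next to the ring nitrogen gives an at least 1.4-fold lower number from compound 1 to compound 3 (0.16 log units; that floor lies within the scatter). The size of that step is only a floor because compound 1 carries a limit and not a number: the limit of > 6600 nM in this assay, at which 1 of the 3 values shown sits. Compound 3 gives 4500 nM, the only firm number among the compounds shown, so this position can carry the larger group, with its three-membered ring and hydrogen-bond donor, and still return a measurable result.

The compounds shown leave open which part of the new group matters: the carbonyl, the amide hydrogen or the three-membered ring. A carboxylic acid or an amine at this place, or an amide with a longer chain instead of the cyclopropyl ring, would help to separate these parts.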